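The source may report more compounds than this note shows. Statements on the series, on what has been measured and on what is new or still open speak of the compounds shown alone.

Of the compounds shown here, three have so far been measured in a functional assay on cells for antagonist activity at Free fatty acid receptor 1 (Homo sapiens), read by TR-FRET and inositol phosphate accumulation, with a stated time of 2 h; a higher number here means a weaker inhibitor, a lower number a stronger inhibitor. Compound 1 `CC(=O)Nc1ccc(OCc2cc(C)nc(-c3ccccn3)n2)cc1` reaches only a limit of the measurement, > 39800 nM. Compound 2 `Cc1cc(COc2cccc(S(C)(=O)=O)c2)nc(-c2ccccn2)n1` likewise stops at a limit, > 39800 nM. Among the compounds with values here, compound 3 `CC1(C)CN(c2cc(COc3ccc(F)c(F)c3F)nc(-c3ccccn3)n2)C1` is the single member that yields a number, 25.1 nM. The other two compounds are described by the limit of > 39800 nM in this assay, at which 2 of the 3 values shown sit. Within the data shown here, because only one compound carries a number, no measured step can be drawn between any two of them.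

Compound 4 `Fc1ccc(OCc2cc(OCC3CCC3)nc(-c3ccccn3)n2)c(F)c1F` has not yet been measured. It differs from compound 3 in a single place: cyclobutylmethoxy in place of 3,3-dimethylazetidin-1-yl on an aromatic carbon. Among the measured compounds shown here, nothing among the measured compounds shows how this assay answers to such an exchange, so the expectation for compound 4 rests on compound 3 and the size of the change alone. The step expected in this assay is a 3.2-fold higher number from compound 3 to compound 4 (0.50 log units; beyond the scatter), a small move toward weaker inhibition that could still fall inside the ordinary scatter. Compound 4 is accordingly estimated at 80 nM in this assay, with the likely range running from 15 nM to 500 nM.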

Compound 4, half-maximal inhibitory concentration: 12.6 nM
Compound 4: the middle estimate sits 6.3-fold (0.80 log units) above what was measured; measured number outside the range, below it.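

In this assay, cyclobutylmethoxy in place of 3,3-dimethylazetidin-1-yl on this aromatic carbon gives a 2.0-fold lower number from compound 3 to compound 4 (0.30 log units; within the scatter), so the two groups cannot be told apart in this assay. The earlier compounds shown here offered no comparison at this position, and this pair shows that the position tolerates a real change of structure without a measurable shift in the result: the atom attached to the aromatic carbon goes from nitrogen to oxygen, and the four-membered ring goes from one holding a hetero atom to one of carbon only. Nothing among the compounds shown gives a reason for this result.

Within the data shown here, the pair covers only two groups with the same count of heavy atoms, so it remains open whether the position would answer in the same way to a primary amine, a carboxylic acid, or a longer chain such as hexyloxy. From the compounds shown here alone, compounds 1 and 2 differ from compound 3 in more than one place, so it also remains open which of those differences separates them from the two compounds that give numbers.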